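The compounds below may be only part of what the source reports. "The series", "measured", "known", "first", "only" and "open" are said of these compounds alone.

Measured compounds:
- compound 1, `CN(C)CCCNc1ccnc2cc(OCc3ccc(F)cc3)ccc12`: 2540 nM
- compound 2, `CCOc1ccc2c(NCCN(C)C)ccnc2c1`: 6240 nM

In a functional assay on DLD-1 cells (Homo sapiens) for cytotoxicity, read by MTT assay, with a stated time of 48 h (on this read-out lower numbers stand for stronger inhibition and higher numbers for weaker inhibition), compound 2 gives 6240 nM, the higher of the two numbers in hand. Compound 1 gives 2540 nM in this assay, and the gap between the two lies beyond the scatter; the two structures differ in more than one place, so nothing is attributed to any single part of that gap.

Compound 3, `CCOc1ccc2c(NCCCN(C)C)ccnc2c1`, has not been measured. It differs from compound 2 in one place: (dimethylamino)methyl in place of dimethylamino on a saturated chain carbon, two bonds along the chain from a nitrogen on an aromatic ring. Among the measured compounds shown here, only this chain change separates compound 3 from compound 2, while compound 1 carries the longer chain together with a different ether group, so the data do not isolate what the chain alone does.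

For the measured compounds named here, the writer expects a modest step downward from compound 2 to compound 3, a 1.6-fold lower number from compound 2 to compound 3 (0.19 log units; within the scatter), leaning on compound 1 at 2540 nM as the only compound with the longer chain, but allowing that the change may fall within the scatter. Compound 3 is estimated at 4000 nM in this assay, with a range from 1500 nM to 10000 nM.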

Compound 3, half-maximal inhibitory concentration: 8540 nM
Estimate against measurement, compound 3: 2.1-fold (0.33 log units) below, and the stated range covers the measured number.
By their numbers in this assay, from the lowest: compound 1; then compounds 2 and 3 (each within the scatter of the next).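

In this assay, (dimethylamino)methyl in place of dimethylamino on a saturated chain carbon, two bonds along the chain from a nitrogen on an aromatic ring, gives a 1.4-fold higher number from compound 2 to compound 3 (0.14 log units; within the scatter), so this change of chain length shows no effect that can be told from the scatter. Among the compounds shown here, with the chain now held the same, the ether group can be read alone for the first time: methyl in place of 4-fluorophenyl on a saturated chain carbon bound to an oxygen on an aromatic ring gives a 3.4-fold higher number from compound 1 to compound 3 (0.53 log units; beyond the scatter), and of the two steps only this one lies beyond the scatter. Nothing at hand speaks to why either step comes out as it does.

The compounds shown leave open whether the chain step would also stay within the scatter with 4-fluorophenyl on the ether, and whether the fluorine matters at all, which a plain phenyl or a 4-chlorophenyl there would help to settle. They also leave open what a pyrrolidine or a morpholine at the end of the chain, in place of dimethylamino, would do in this assay.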